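Methoxy in Place of Trifluoromethyl: What the Limits Allow

The source may hold more compounds than are shown below. What is called first, only, known or untested is meant among the compounds shown, and "the series" means these compounds.

Three compounds share one core and differ only in the groups on their outer rings. Compound 1 `COc1ccc(N/C=C\C(=O)c2cn(-c3ccccc3)nc2-c2ccccc2)cc1` was tested in an ADME assay on HaCaT cells (Homo sapiens) for antiproliferative activity, read by MTT assay, with a stated time of 48 h; on this read-out lower numbers stand for stronger inhibition and higher numbers for weaker inhibition. In that assay compound 1 gives only a limit, > 50000 nM. Compound 2 `O=C(/C=C\Nc1ccc(F)cc1)c1cn(-c2ccccc2)nc1-c1ccc(Cl)cc1` likewise gives a limit, > 50000 nM. Compound 3 `O=C(/C=C\Nc1ccc(C(F)(F)F)cc1)c1cn(-c2ccccc2)nc1-c1ccc(Cl)cc1` also stands at a limit, > 50000 nM, so its place among the three cannot be ranked. Within the data shown here, the one measured step, a step that the two limits leave unreadable from compound 2 to compound 3, cannot be read because of the limit of > 50000 nM in this assay, at which 3 of the 3 values shown sit. Compound 4 `COc1ccc(N/C=C\C(=O)c2cn(-c3ccccc3)nc2-c2ccc(Cl)cc2)cc1` differs from compound 3 by methoxy in place of trifluoromethyl on an aromatic carbon. Among the measured compounds shown here, no measured step tells the size of that change, so the step that the limit leaves unreadable from compound 3 to compound 4 is expected to be none beyond the scatter. Compound 4 is therefore expected to give 80000 nM, within 20000 nM to 300000 nM.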

Compound 4, half-maximal inhibitory concentration: 30800 nM
Compound 4: middle estimate off by 2.6-fold (0.41 log units), on the high side, and the stated range covers the measured number.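

With methoxy in place of trifluoromethyl, the series gives its first real number rather than a limit, and the change reads as an at least 1.6-fold lower number from compound 3 to compound 4 (0.21 log units; that floor lies within the scatter). Methoxy in place of fluoro reads as an at least 1.6-fold lower number from compound 2 to compound 4 (0.21 log units; that floor lies within the scatter), and chloro in place of hydrogen reads as an at least 1.6-fold lower number from compound 1 to compound 4 (0.21 log units; that floor lies within the scatter). Each of these is only a floor, because compound 1, compound 2 and compound 3 each stand at a limit: the limit of > 50000 nM in this assay, at which 3 of the 4 values shown sit.

The step between compound 2 and compound 3 still cannot be read. Also open, on these data alone, is whether an amine or a carboxylic acid in place of methoxy would give a lower number than compound 4.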